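Exchanging one hydroxy-bearing chain on a sulfur

The source may hold more compounds than are shown below. What is called first, only, known or untested is meant among the compounds shown, and "the series" means these compounds.

compound 1 `CC(C)c1n[nH]c2c(NCc3ccc(-c4ccccn4)cc3)nc(SCC(N)CN)nc12`: 480 nM
compound 2 `CC(C)c1n[nH]c2c(NCc3ccc(-c4ccccn4)cc3)nc(SC(CO)C(C)C)nc12`: 980 nM

In a functional assay on HT cells (Homo sapiens) for antiproliferative activity, read by fluorescence, with a stated time of 72 h (on this read-out higher numbers stand for weaker inhibition of growth and lower numbers for stronger inhibition of growth), compound 2 gives 980 nM and holds the higher of the two numbers, so it shows the weaker inhibition of growth of the pair. Compound 3 `CC(C)c1n[nH]c2c(NCc3ccc(-c4ccccn4)cc3)nc(SC(C)C(C)O)nc12` has not yet been measured and keeps the shared core of compound 2. The only difference lies on a sulfur whose other neighbour is an aromatic carbon: 2-hydroxy-1-methylpropyl in place of 1-(hydroxymethyl)-2-methylpropyl on a sulfur and nothing else changes. Among the measured compounds shown here, one measured step bears on this place, a 2.0-fold higher number from compound 1 to compound 2 (0.31 log units; beyond the scatter) and it is modest though beyond the scatter. For the measured compounds named here, that step involved the quite different 2,3-diaminopropyl group, and no measured pair compares two hydroxy-bearing chains directly. Going by the values given here, with compound 2 and the modest size of a 2.0-fold higher number from compound 1 to compound 2 (0.31 log units; beyond the scatter) as the only guides, a step of no greater size is expected, with no firm direction and probably none beyond the scatter. The estimated step is a 1.2-fold lower number from compound 2 to compound 3 (0.09 log units; within the scatter) in this series. For compound 3 the expected value is 800 nM with an estimated range from 350 nM to 1800 nM in this assay once it is measured.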

Compound 3, concentration for 50% growth inhibition: 190 nM
Compound 3: the middle estimate sits 4.2-fold (0.62 log units) above what was measured; the whole stated range lies above it.
By their numbers in this assay, from the lowest: compound 3; then compound 1; then compound 2.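

In this assay, the step from 1-(hydroxymethyl)-2-methylpropyl to 2-hydroxy-1-methylpropyl on a sulfur gives a 5.2-fold lower number from compound 2 to compound 3 (0.71 log units; beyond the scatter), so this position distinguishes between two uncharged, unringed hydroxy-bearing chains of 6 and 5 heavy atoms that have the same hydrogen-bond donor and acceptor counts. The exchange of 2,3-diaminopropyl for 2-hydroxy-1-methylpropyl gives a 2.5-fold lower number from compound 1 to compound 3 (0.40 log units; beyond the scatter), whereas the exchange for 1-(hydroxymethyl)-2-methylpropyl gave a 2.0-fold higher number from compound 1 to compound 2 (0.31 log units; beyond the scatter), so the hydroxy-bearing chains fall on opposite sides of compound 1 and the mere presence of a hydroxy group does not set the order among these three compounds. Nothing available explains why the two hydroxy-bearing chains differ in this way.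

The change from compound 2 to compound 3 alters the place of the hydroxy group and the heavy-atom count together, so the compounds shown cannot separate these two differences. Going by these compounds, it also remains open how this position would respond if the hydroxy group of 2-hydroxy-1-methylpropyl were replaced by a primary amine, a methyl ether or a carboxylic acid.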